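Sulfonyl for carbonyl on the ring nitrogen of compound 3

The compounds below may be only part of what the source reports. "The series", "measured", "known", "first", "only" and "open" are said of these compounds alone.

The three measured compounds share one core and differ only in the group on the ring nitrogen. Compound 1 `CN(C)c1ccc(C2CC(c3ccc(-n4cncn4)cc3)=NN2C(=O)CCCl)cc1` gives -3.4% in a functional assay on HCC1806 cells (Homo sapiens) for inhibition, read by sulforhodamine B assay, tested at 10 uM; on this read-out lower numbers stand for less inhibition and higher numbers for more inhibition at the one concentration tested (going by the name of the read-out). Compound 2 `CN(C)c1ccc(C2CC(c3ccc(-n4cncn4)cc3)=NN2C(=O)c2ccc(F)cc2)cc1` gives 15.6%, and compound 3 `CN(C)c1ccc(C2CC(c3ccc(-n4cncn4)cc3)=NN2C(=O)c2ccc(C(F)(F)F)cc2)cc1` gives 7%. Compound 3 thus stands second highest of the three numbers: its nearest neighbour is compound 2, with a number 8.6 percentage points lower from compound 2 to compound 3 (within the scatter), and its furthest is compound 1, with a number 10.4 percentage points higher from compound 1 to compound 3 (beyond the scatter).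

The unmeasured compound 4 `CN(C)c1ccc(C2CC(c3ccc(-n4cncn4)cc3)=NN2S(=O)(=O)c2ccc(Br)cc2)cc1` differs from compound 3 in one place: (4-bromophenyl)sulfonyl in place of (4-(trifluoromethyl)phenyl)carbonyl on an amine nitrogen in a ring.

Two of the measured steps bear on this change in a loose way. Replacing the 2-chloroethyl group on the carbonyl carbon by an aryl group gave a number 19 percentage points higher from compound 1 to compound 2 (beyond the scatter) and a number 10.4 percentage points higher from compound 1 to compound 3 (beyond the scatter), both modest. Exchanging the substituent on the aromatic carbon gave a number 8.6 percentage points lower from compound 2 to compound 3 (within the scatter), within the scatter. Within the data shown here, no measured pair tests a sulfonyl in place of a carbonyl, so the data give no direction for that part of the change. The expected step is therefore a number 1 percentage points higher from compound 3 to compound 4 (within the scatter), none beyond the scatter. Compound 4 is estimated to give 8%, with a range from -8% to 24%.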

Compound 4, a percentage reported as inhibition, at one concentration (the size of the read-out at that concentration, not a potency): 26.3%
Compound 4: the middle estimate sits 18.3 percentage points below what was measured; measured number above the stated range.
By their numbers in this assay, from the lowest: compound 1; then compounds 3 and 2 (each within the scatter of the next); then compound 4.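

In this assay, the (4-bromophenyl)sulfonyl group on the amine nitrogen in the ring gives the highest number of the four compounds, with steps to all three others beyond the scatter: a number 19.3 percentage points higher from compound 3 to compound 4 (beyond the scatter), a number 10.7 percentage points higher from compound 2 to compound 4 (beyond the scatter) and a number 29.7 percentage points higher from compound 1 to compound 4 (beyond the scatter). The two aryl carbonyl compounds had stayed within the scatter of each other, so they had not shown that a change at this nitrogen could lift the number clear of both, although the gain remains modest. No measurement offered here explains the rise.

Compound 4 differs from the other compounds in both the link to the nitrogen and the group on the aromatic ring, so the share of the sulfonyl cannot be separated from that of the bromine; (4-bromophenyl)carbonyl and (4-(trifluoromethyl)phenyl)sulfonyl on the same nitrogen would divide the two. From the compounds shown here alone, it also stays open whether the number depends on an aromatic ring at all, as a 2-chloroethylsulfonyl or methylsulfonyl group would show, and whether an amine or a carboxylic acid on the ring in place of the bromine would keep it.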